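This account rests on a few compounds, and the source may have more. Where it says the series, first, only, none or still open, it means among the compounds named here.

Compound 1 `Cn1cc(C2=C(c3nn(CCn4ccnc4)c4ncccc34)C(=O)NC2=O)c2ccccc21` gives in a functional assay on K562 cells (Homo sapiens) for antiproliferative activity, read by MTT assay, with a stated time of 48 h (on this read-out lower numbers stand for stronger inhibition and higher numbers for weaker inhibition), only a limit, > 100000 nM.
Compound 2 `CN(C)CCCn1nc(C2=C(c3cn(C)c4ccccc34)C(=O)NC2=O)c2cccnc21` gives 50400 nM in this assay.
Compound 3 `CN1CCN(CCCn2nc(C3=C(c4cn(C)c5ccccc45)C(=O)NC3=O)c3cccnc32)CC1` gives 46700 nM in this assay.

Compound 3 holds the lowest of the two numbers shown, but its neighbour is compound 2, and a 1.1-fold lower number from compound 2 to compound 3 (0.03 log units; within the scatter) keeps the two inside the scatter, so no order between them is claimed. Compound 4 `Cn1cc(C2=C(c3nn(CCCn4cccc4)c4ncccc34)C(=O)NC2=O)c2ccccc21` is not yet measured. It differs from compound 3 by 1H-pyrrol-1-yl in place of 4-methylpiperazin-1-yl on a saturated chain carbon, three bonds along the chain from an aromatic nitrogen.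

For the measured compounds named here, two measured steps bear on this change. Both concern the exchange of an aromatic azole for an amine on the chain: an at least 1.9-fold lower number from compound 1 to compound 2 (0.29 log units; that floor lies within the scatter) and an at least 2.1-fold lower number from compound 1 to compound 3 (0.33 log units; beyond the scatter). The step to compound 4 runs the other way, putting an aromatic ring back in place of an amine, so the expected movement is toward a higher number. Because compound 1 sits at the limit of > 100000 nM in this assay, at which 1 of the 3 values shown sits, the prose author considers it likely that compound 4 also reaches only a limit. The step that the estimate means is a 2.1-fold higher number from compound 3 to compound 4 (0.33 log units; beyond the scatter), expected to lie beyond the scatter in the direction of weaker inhibition. For compound 4 the estimate in this assay is 100000 nM, ranging from 40000 nM to 300000 nM.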

Compound 4, half-maximal inhibitory concentration: 21600 nM
The estimate for compound 4 lay 4.6-fold (0.67 log units) above the measured number, outside the stated range (below it).
By their numbers in this assay, from the lowest: compound 4; then compounds 3 and 2 (each within the scatter of the next). At a limit, above all of these: compound 1.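

In this assay, the end of the chain, three bonds along from an aromatic nitrogen, need not carry an amine: 1H-pyrrol-1-yl in place of 4-methylpiperazin-1-yl gives a 2.2-fold lower number from compound 3 to compound 4 (0.33 log units; beyond the scatter), and in place of dimethylamino it gives a 2.3-fold lower number from compound 2 to compound 4 (0.37 log units; beyond the scatter), both modest steps. An aromatic ring on the chain therefore does not in itself go with weak inhibition, and the comparison with the imidazole compound gives an at least 4.6-fold lower number from compound 1 to compound 4 (0.66 log units; beyond the scatter), where (1H-pyrrol-1-yl)methyl stands in place of 1H-imidazol-1-yl and the size of the step is only a floor. Compound 1 goes against any simple link between an aromatic ring on the chain and a lower number, and it alone stays at a limit: the limit of > 100000 nM in this assay, at which 1 of the 4 values shown sits.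

The step from compound 1 changes the ring and the chain together, so a 3-(1H-imidazol-1-yl)propyl or a 2-(1H-pyrrol-1-yl)ethyl chain would be needed to separate the two. From the compounds shown here alone, how a phenyl ring or a longer chain at this position would read remains open.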